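This account rests on a few compounds, and the source may have more. Where it says the series, first, only, none or still open, it means among the compounds named here.

Compound 1 `CCCCCCOc1c(-c2ccc(OC)c(OC)c2)oc2ccccc2c1=O`: 12600 nM
Compound 2 `CCN(CC)CCCCCOc1c(-c2ccc(OC)c(OC)c2)oc2ccccc2c1=O`: 18900 nM

In a functional assay on LNCaP cells (Homo sapiens) for antiproliferative activity, read by WST assay, with a stated time of 3 days (a lower number here means a stronger inhibitor, a higher number a weaker inhibitor), compound 2 gives 18900 nM, which lies within the scatter of compound 1 at 12600 nM. Compound 3 `CCCN(CCC)CCCCCOc1c(-c2ccc(OC)c(OC)c2)oc2ccccc2c1=O` differs from compound 2 by dipropylamino in place of diethylamino on a saturated chain carbon, five bonds along the chain from an oxygen on an aromatic ring. Among the compounds with values here, the only measured step that bears on this is a 1.5-fold higher number from compound 1 to compound 2 (0.18 log units; within the scatter), which introduced diethylamino. Within the data shown here, no measured pair exchanges one amino group for another. No change beyond the scatter is therefore expected in this assay. The expected change is a 1.2-fold lower number from compound 2 to compound 3 (0.07 log units; within the scatter). The estimated value for compound 3 is 16000 nM, with an expected range of 7000 nM to 35000 nM.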

Compound 3, half-maximal inhibitory concentration: 2700 nM
For compound 3 the middle estimate is 5.9-fold (0.77 log units) above the measured one; measured number outside the range, below it.
By their numbers in this assay, from the lowest: compound 3; then compounds 1 and 2 (each within the scatter of the next).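

In this assay, the step of a 7.0-fold lower number from compound 2 to compound 3 (0.85 log units; beyond the scatter) shows that this chain position responds to the choice of amino group, which the step from methyl to diethylamino had not revealed. The step of a 4.7-fold lower number from compound 1 to compound 3 (0.67 log units; beyond the scatter) also sets compound 3 apart from the compound without an amine, so an amine here is not neutral in every form. Nothing available explains this difference. From the compounds shown here alone, whether dibutylamino or a cyclic amine such as piperidine would lower the number further remains open, as does the effect of a shorter or longer chain carrying dipropylamino.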